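Phenyl in Place of Pyridin-2-yl on a Shared Core

The compounds below may be only part of what the source reports. "The series", "measured", "known", "first", "only" and "open" are said of these compounds alone.

Compound 1 `C=C1C[C@]23C[C@@]1(O)CC[C@@H]2c1cccc(C)c1[C@@H]3Cn1cc(-c2ccc(Cl)cc2)nn1` and compound 2 `C=C1C[C@]23C[C@@]1(O)CC[C@@H]2c1cccc(C)c1[C@@H]3Cn1cc(-c2ccccn2)nn1` share one core and differ only in the aromatic group carried on it. In a functional assay on MCF7 cells (Homo sapiens) for cytotoxicity, read by MTT assay, with a stated time of 4 days (on this read-out higher numbers stand for weaker inhibition and lower numbers for stronger inhibition), compound 1 gives a value that is a limit of the assay, > 20000 nM. In this assay compound 2 likewise gives only a limit, > 20000 nM. The step that the two limits leave unreadable from compound 1 to compound 2 therefore cannot be read, and all that the measurements show is the limit of > 20000 nM in this assay, at which 2 of the 2 values shown sit. Compound 2 thus stands at a limit of this assay rather than at a number, and no ordering between compound 1 and compound 2 can be drawn.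

Compound 3 `C=C1C[C@]23C[C@@]1(O)CC[C@@H]2c1cccc(C)c1[C@@H]3Cn1cc(-c2ccccc2)nn1` is the next change: phenyl in place of pyridin-2-yl on an aromatic carbon. Within the data shown here, the only measured step, the one from compound 1 to compound 2, is unreadable, so nothing among the measured steps points to a readable change in this assay for this replacement. Compound 3 is therefore expected to sit at a limit again, with an estimate of 30000 nM and a range from 10000 nM to 100000 nM. The step that the limit leaves unreadable from compound 2 to compound 3 implied by this estimate is expected to stay unreadable.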

Compound 3, half-maximal inhibitory concentration: > 20000 nM
Compound 3: no number, only a limit; the forecaster's own chance of this, stated with the estimate: 80%; the middle value does not contradict the limit.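

In this assay compound 3 gives > 20000 nM as a limit of the assay, not a number. Among these compounds, no step among compound 1, compound 2 and compound 3 can therefore be read. The compounds shown leave open whether changing the aromatic group on the shared core alters cytotoxicity at all, as none of the three gives a number.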